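A few compounds are considered here, and "the series" means these few. Any claim that something is new, unique, unknown or untested is made for them only; others in the source may bear on it.

Compound 1, `O=C(Nc1cc(Br)cc2c(=O)cc(C(=O)O)oc12)c1ccccc1`: in an assay on CHO cells for agonist activity at G protein-coupled receptor GPR35 (Rattus norvegicus), read by a beta-galactosidase reporter and beta-arrestin recruitment, with a stated time of 90 min (on this read-out lower numbers stand for an effect already at smaller amounts and higher numbers for an effect only at larger amounts of compound), compound 1 gives 2750 nM.
Compound 2, `CCOc1ccc(C(=O)Nc2cc(Br)cc3c(=O)cc(C(=O)O)oc23)cc1`: in this assay compound 2 gives 1360 nM.

Going by the values given here, of these two numbers, compound 2 has the lower one, and the only neighbour is compound 1; the step of a 2.0-fold lower number from compound 1 to compound 2 (0.31 log units; beyond the scatter) shows how far they sit apart. The next compound, compound 3, `N#Cc1ccc(C(=O)Nc2cc(Br)cc3c(=O)cc(C(=O)O)oc23)cc1`, changes the group on the same aromatic carbon again: cyano in place of ethoxy on an aromatic carbon. The carbon in question is the one para to a large group.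

Among the compounds with values here, only one measured step bears on this change, the one from compound 1 to compound 2, and it concerns ethoxy against hydrogen, not cyano. It shows that the group on this carbon can shift the number modestly, but it gives no direct guide for cyano. Within the data shown here, with no measured cyano analogue, the expectation is cautious: the step of a 1.5-fold higher number from compound 2 to compound 3 (0.17 log units; within the scatter) is expected to stay close to the scatter, if anything towards a higher number. For compound 3 the estimated value in this assay is therefore 2000 nM, with a range from 800 nM to 5000 nM.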

Compound 3, half-maximal effective concentration: 2260 nM
Compound 3: middle estimate off by 1.1-fold (0.05 log units), on the low side, and the stated range covers the measured number.
By their numbers in this assay, from the lowest: compounds 2, 3 and 1 (each within the scatter of the next, the first and the last beyond it).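

In this assay, cyano can now be set against both earlier groups on this carbon: the step of a 1.7-fold higher number from compound 2 to compound 3 (0.22 log units; within the scatter) compares it with ethoxy, and the step of a 1.2-fold lower number from compound 1 to compound 3 (0.09 log units; within the scatter) compares it with hydrogen. Both steps lie within the scatter, so cyano cannot be told apart from either group, even though ethoxy and hydrogen are themselves separated by a step beyond the scatter, a 2.0-fold lower number from compound 1 to compound 2 (0.31 log units; beyond the scatter). No measurement shown here accounts for these numbers, so the result describes what happens at this position without explaining it.

The three compounds leave open whether an amine, a carboxylic acid or a longer chain such as butoxy on this same carbon would give a number clearly apart from that of compound 1, and in which direction. They also leave open whether ethoxy would give a similar step when placed on another carbon of the six-membered aromatic ring, or whether the step from hydrogen to ethoxy would hold with a different group in place of the bromine on the shared core.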